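The source may report more compounds than this note shows. Statements on the series, on what has been measured and on what is new or still open speak of the compounds shown alone.

Measured in a functional assay on HCT-116 cells (Homo sapiens) for inhibition, read by CCK-8 assay, with a stated time of 48 h; on this read-out higher numbers stand for weaker inhibition and lower numbers for stronger inhibition:
Compound 1 `COc1ccc(CN(C(=O)CSC(=S)N2CCN(C(C)=O)CC2)c2cc(OC)c(OC)c(OC)c2)cc1`: 1370 nM
Compound 2 `COc1ccc(CN(C(=O)CSC(=S)N2CCN(C(=O)OC(C)(C)C)CC2)c2cc(OC)c(OC)c(OC)c2)cc1`: 620 nM

Compound 2 stands lowest of these two numbers. Within the data shown here, the only measured step is a 2.2-fold lower number from compound 1 to compound 2 (0.34 log units; beyond the scatter), made on a carbonyl carbon. Compound 3 `COc1ccc(CN(C(=O)CSC(=S)N2CCN(C(=O)OC(C)(C)C)CC2)c2ccccc2)cc1` changes another place: phenyl in place of 3,4,5-trimethoxyphenyl on an amide-type nitrogen. Among the measured compounds shown here, no measured step touches that amide-type nitrogen, so the earlier step of a 2.2-fold lower number from compound 1 to compound 2 (0.34 log units; beyond the scatter) offers only a rough scale. A move to a higher number in this assay, somewhat larger than that step, is expected, though the data do not settle its direction. The expected step is a 2.4-fold higher number from compound 2 to compound 3 (0.38 log units; beyond the scatter). For compound 3 the estimated value is 1500 nM, with an expected range of 400 nM to 6000 nM.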

Compound 3, half-maximal inhibitory concentration: > 20000 nM
Compound 3: only a limit was reported; the forecaster's own chance of this, stated with the estimate: 10%; middle value at least 13-fold (1.12 log units) from the limit.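

Replacing 3,4,5-trimethoxyphenyl with phenyl on the amide-type nitrogen gives an at least 32-fold higher number from compound 2 to compound 3 (1.50 log units; beyond the scatter) in this assay, which is much larger than the earlier change on the carbonyl carbon, a 2.2-fold lower number from compound 1 to compound 2 (0.34 log units; beyond the scatter). This shows that, for these compounds, the group on this nitrogen matters more to the read-out than the one changed earlier. The value for compound 3 is a limit, not a number: the limit of > 20000 nM in this assay, at which 1 of the 3 values shown sits.

The compounds shown leave open how a phenyl ring carrying a single methoxy group or a chlorine atom would read on this nitrogen. They also leave open whether the methoxy groups act together or singly.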